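Solubility limits in the imide series: compound 2 to compound 3

The source may report more compounds than this note shows. Statements on the series, on what has been measured and on what is new or still open speak of the compounds shown alone.

Two compounds of this series have gone through a physicochemical assay for solubility, using the shake flask method, in simulated intestinal fluid, measured as kinetic solubility, with a stated time of 2 h, at 25 degrees C, at pH 6.5 (on this read-out higher numbers stand for higher solubility and lower numbers for lower solubility), so far, and neither returned a number. Compound 1 `Cc1nc(C#N)c(N)c2c1C(=O)N(Cc1ccccc1)C2=O` reached only the limit of the assay, < 5000 nM. Compound 2 `Cc1noc(-c2nc(C)c3c(c2N)C(=O)N(Cc2ccc(-c4ccncc4)cc2)C3=O)n1` likewise stopped at the limit, < 5000 nM. Both readings rest on (the limit of < 5000 nM in this assay, at which 2 of the 2 values shown sit), so compound 2 stands at the floor of what has been measured, with nothing to separate it from compound 1 on the numbers in hand.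

Compound 3 `Cc1noc(-c2nc(C)c3c(c2N)C(=O)N(Cc2ccc(C(N)=O)cc2)C3=O)n1` is the next member to be taken into this assay. It differs from compound 2 in one place: carbamoyl in place of pyridin-4-yl on an aromatic carbon. Within the data shown here, no step between two measured compounds is on record for this kind of change, so no measured size can be set against it, and the direction remains open.

The expectation for compound 3 in this assay is a step of a number no lower from compound 2 to compound 3 (the limit leaves the size open), small against the usual scatter but carrying wide uncertainty. Compound 3 is expected to give 5000 nM, in the range 1000 nM to 25000 nM, with a fair chance that the assay once more reports only a limit rather than a number.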

Compound 3, solubility: < 5000 nM
Compound 3: no number, only a limit; the forecaster's own chance of this, stated with the estimate: 55%; the middle value sits exactly at the limit.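

In this assay compound 3 gives < 5000 nM, a limit of the assay and not a number. Compound 2 also stands at a limit, so no step can be read between compound 2 and compound 3. The compounds shown leave open how far each lies under that limit, and whether carbamoyl or pyridin-4-yl gives the higher solubility.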